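Lengthening the Ester Chain of Compound 3

The source may hold more compounds than are shown below. What is called first, only, known or untested is meant among the compounds shown, and "the series" means these compounds.

In an ADME assay on HepG2 2.2.15 cells (Homo sapiens) for cytotoxicity (on this read-out higher numbers stand for lower toxicity in this test and lower numbers for higher toxicity in this test), compound 1 `C=CCn1c(=O)c(CCO)c(-c2ccccc2Cl)c2cc(Cl)ccc21` gives 23000 nM, compound 2 `O=CCc1c(-c2ccccc2Cl)c2cc(Cl)ccc2[nH]c1=O` gives 120000 nM and compound 3 `CCC(=O)OCCc1c(-c2ccccc2Cl)c2cc(Cl)ccc2[nH]c1=O` gives 95000 nM. Compound 3 thus holds the second highest of the three numbers, within the scatter of compound 2 and clearly higher than compound 1. Compound 4 `CCCCCCCC(=O)OCCc1c(-c2ccccc2Cl)c2cc(Cl)ccc2[nH]c1=O` carries pentyl in place of hydrogen on a saturated chain carbon, two bonds along the chain from a carbonyl carbon. Among the measured compounds shown here, the only measured step bearing on this is a 1.3-fold lower number from compound 2 to compound 3 (0.10 log units; within the scatter), and it does not vary chain length. No change beyond the scatter is therefore expected in this assay, with only a slight lean towards a lower number. The expected step is a 1.4-fold lower number from compound 3 to compound 4 (0.13 log units; within the scatter). Compound 4 is estimated at 70000 nM, within an expected range of 30000 nM to 130000 nM.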

Compound 4, half-maximal cytotoxic concentration: 78000 nM
Compound 4: middle estimate off by 1.1-fold (0.05 log units), on the low side; measured number inside the range.
By their numbers in this assay, from the lowest: compound 1; then compounds 4, 3 and 2 (each within the scatter of the next).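

Pentyl in place of hydrogen on a saturated chain carbon, two bonds along the chain from a carbonyl carbon, yields a 1.2-fold lower number from compound 3 to compound 4 (0.09 log units; within the scatter) in this assay and stays within the scatter. This position therefore tolerates going from propanoyl to heptylcarbonyl without a change beyond the scatter on this read-out, which compound 3 alone could not show. Nothing available here bears on this result. From the compounds shown here alone, whether a longer chain, or an amine or a carboxylic acid at the chain end, would behave alike stays open.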